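Five-membered heteroaryl in place of pyrimidine on the core

The compounds below may be only part of what the source reports. "The series", "measured", "known", "first", "only" and "open" are said of these compounds alone.

Among the compounds with values here, compound 1 `c1cnc(-c2ccccc2OCC2=NCCN2)nc1` gives 1260 nM in a functional assay for activation of Alpha-1A adrenergic receptor (Homo sapiens), read by calcium flux (a higher number here means that more compound is needed for the effect, a lower number that less compound is needed), the highest of the three numbers measured so far. Compound 2 `c1ccc(-c2ccoc2)c(OCC2=NCCN2)c1` gives 0.501 nM and compound 3 `c1ccc(-c2ccns2)c(OCC2=NCCN2)c1` gives 5.01 nM in this assay. The change to compound 4 `Cc1ccoc1-c1ccccc1OCC1=NCCN1` is 3-methylfuran-2-yl in place of pyrimidin-2-yl on an aromatic carbon. Within the data shown here, two measured steps bear on it: a 2500-fold lower number from compound 1 to compound 2 (3.40 log units; beyond the scatter) and a 250-fold lower number from compound 1 to compound 3 (2.40 log units; beyond the scatter), both large drops on exchanging the six-membered aromatic ring for a five-membered one. The step of a 10-fold higher number from compound 2 to compound 3 (1.00 log units; beyond the scatter) shows that the size of the drop depends on which five-membered ring enters. A large downward step is therefore expected for compound 4, estimated as a 250-fold lower number from compound 1 to compound 4 (2.40 log units; beyond the scatter). Compound 4 is expected to give 5 nM, within 0.5 nM to 50 nM.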

Compound 4, half-maximal effective concentration: 3.16 nM
Beside the measured number, compound 4's estimate is 1.6-fold (0.20 log units) above it, within the range that was stated.
By their numbers in this assay, from the lowest: compound 2; then compounds 4 and 3 (each within the scatter of the next); then compound 1.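

A third five-membered ring, 3-methylfuran-2-yl, also gives a large drop on leaving pyrimidin-2-yl in this assay (a 400-fold lower number from compound 1 to compound 4 (2.60 log units; beyond the scatter)), so the drop holds for all three five-membered rings shown. The methylfuran cannot be told apart from 1,2-thiazol-5-yl (a 1.6-fold lower number from compound 3 to compound 4 (0.20 log units; within the scatter)), while furan-3-yl remains separate from it (a 6.3-fold higher number from compound 2 to compound 4 (0.80 log units; beyond the scatter)). Nothing available explains these differences. On these data alone, whether the gap to compound 2 follows the methyl or the furan's point of attachment stays open, and plain furan-2-yl would bear on that. As far as these compounds go, what an amine or a carboxylic acid in place of the methyl would give also remains open.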